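The source may report more compounds than this note shows. Statements on the series, on what has been measured and on what is new or still open speak of the compounds shown alone.

Compound 1, `CCCOC(=O)Nc1ccc([Se]C#N)cc1`: 28400 nM
Compound 2, `O=C(Nc1ccc([Se][Se]c2ccc(NC(=O)Oc3ccccc3)cc2)cc1)Oc1ccccc1`: 13000 nM
Compound 3, `N#C[Se]c1ccc(NC(=O)Oc2ccc(Cl)cc2)cc1`: 11800 nM

Of the compounds shown here, three have been measured in a functional assay on HT-29 cells (Homo sapiens) for cytotoxicity, read by MTT assay, with a stated time of 72 h; on this read-out lower numbers stand for stronger inhibition of growth and higher numbers for weaker inhibition of growth. Among them compound 1 stands at the highest of the three numbers, so on this read-out it is the weakest of the measured set. Compound 2 lies nearest to it and compound 3 furthest, and both of those gaps are beyond the scatter of repeated measurements, so compound 1 is genuinely set apart from the other two rather than merely scattered around the same value.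

The next compound, compound 4, `CCCCCCOC(=O)Nc1ccc([Se]C#N)cc1`, keeps the whole core of compound 1 and changes one thing: propyl in place of hydrogen on a saturated chain carbon, three bonds along the chain from an oxygen next to a carbonyl group. Among the measured compounds shown here, no pair of measured compounds shows this particular change, so there is no measured step to lean on, and what follows is an expectation only. Lengthening the chain in this way is expected to move the number somewhat, towards lower values, by about a 1.8-fold lower number from compound 1 to compound 4 (0.25 log units; within the scatter), a shift that may or may not clear the usual scatter. On that basis compound 4 is estimated to give roughly 16000 nM in this assay, with a plausible range from 5000 nM to 45000 nM.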

Compound 4, concentration for 50% growth inhibition: 10700 nM
Compound 4: middle estimate off by 1.5-fold (0.17 log units), on the high side; low and high end bracket the measured number.
By their numbers in this assay, from the lowest: compounds 4, 3 and 2 (each within the scatter of the next); then compound 1.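

In this assay, lengthening the chain from propyl to hexyl, which places propyl in place of hydrogen on a saturated chain carbon, three bonds along the chain from an oxygen next to a carbonyl group, gives a 2.7-fold lower number from compound 1 to compound 4 (0.42 log units; beyond the scatter) and is a modest but real change. Among the compounds shown here, this is the first step in the set that alters one place only, whereas the earlier compounds differ from one another in more than one place and could not single out the effect of this chain. It shows that this end of the molecule can carry a clearly longer chain with growth inhibition somewhat stronger rather than lost, although nothing in the data explains why the number falls.

A single step joins only two points, so it cannot show whether the number would keep falling with chain length, level off or rise again with a longer chain such as octyl. Also open, from the compounds shown here alone, is how this position would respond to a shorter chain such as ethyl, a branched chain such as isopropyl, or a chain ending in an amine or a carboxylic acid.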